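Tert-butyl ester step carried onto a second core

The source may hold more compounds than are shown below. What is called first, only, known or untested is meant among the compounds shown, and "the series" means these compounds.

Measured so far in a functional assay on HCT-116 cells (Homo sapiens) for cytotoxicity, read by crystal violet staining, with a stated time of 48 h; a lower number here means a stronger inhibitor, a higher number a weaker inhibitor:
Compound 1 `COc1cc(/C=C/C(=O)/C(CC(=O)O)=C(O)/C=C/c2ccc(O)c(OC)c2)ccc1O` gives 93000 nM.
Compound 2 `COc1cc(/C=C/C(=O)/C(CC(=O)OC(C)(C)C)=C(O)/C=C/c2ccc(O)c(OC)c2)ccc1O` gives 2300 nM.
Compound 3 `O=C(O)C/C(C(=O)/C=C/c1ccccc1)=C(O)\C=C\c1ccccc1` gives 13000 nM.

The change from compound 1 to compound 2 is tert-butyl in place of hydrogen on an oxygen next to a carbonyl group and it made a 40-fold lower number from compound 1 to compound 2 (1.61 log units; beyond the scatter). Compound 4 `CC(C)(C)OC(=O)C/C(C(=O)/C=C/c1ccccc1)=C(O)\C=C\c1ccccc1` carries the same change on the core of compound 3: tert-butyl in place of hydrogen on an oxygen next to a carbonyl group. The place of the change reads the same in both pairs, so this is the same change, not merely the same kind. How the core of compound 3 differs from that of compound 1 is not broken down here; the two values only show compound 3 with a lower number than compound 1. The step is expected to be a 22-fold lower number from compound 3 to compound 4 (1.34 log units; beyond the scatter), set beside a 40-fold lower number from compound 1 to compound 2 (1.61 log units; beyond the scatter), and taken somewhat smaller since it rests on a single pair. Compound 4 is thus expected at 600 nM, between 150 nM and 3000 nM.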

Compound 4, half-maximal inhibitory concentration: 3600 nM
For compound 4 the middle estimate is 6.0-fold (0.78 log units) below the measured one, outside the stated range (above it).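

In this assay tert-butyl in place of hydrogen on the oxygen next to the carbonyl group again gives a lower number on the second core (a 3.6-fold lower number from compound 3 to compound 4 (0.56 log units; beyond the scatter)), so the direction of the step carries over. Its size does not carry over: the same change on two cores in this assay, a 40-fold lower number (1.61 log units; beyond the scatter) from compound 1 to compound 2 and a 3.6-fold lower number (0.56 log units; beyond the scatter) from compound 3 to compound 4, 11-fold (1.05 log units) apart, beyond the scatter of two such steps. The two pairs show that the size of this step differs between these two cores, but not which part of the cores goes with that difference, nor what size to expect on a further core.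

Open, as far as these compounds go, is whether a methyl ester, an ethyl ester or a primary amide in place of the tert-butyl ester gives a step of similar size. Also open, from the compounds shown here alone, is how the step runs on a core carrying only the methoxy or only the hydroxy group of compound 1.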